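This account rests on a few compounds, and the source may have more. Where it says the series, first, only, none or still open, it means among the compounds named here.

Measured in a functional assay on COLO 205 cells (Homo sapiens) for cytotoxicity, read by sulforhodamine B assay, with a stated time of 48 h; on this read-out lower numbers stand for stronger inhibition and higher numbers for weaker inhibition:
- compound 1 `COc1cccc(/C=C/C(=O)/C=C/c2ccc(OCc3cn(CCOc4cc(=O)oc5ccccc45)nn3)c(OC)c2)c1`: 11900 nM
- compound 2 `COc1cc(/C=C/C(=O)/C=C/c2ccco2)ccc1OCc1cn(CCOc2cc(=O)oc3ccccc23)nn1`: 11800 nM

Among the measured compounds shown here, compound 2 stands level with compound 1, the only other compound measured, and their two numbers lie within the scatter of each other. Compound 3 `COc1ccc(/C=C/C(=O)/C=C/c2ccc(OCc3cn(CCOc4cc(=O)oc5ccccc45)nn3)c(OC)c2)cc1` has not yet been measured. It carries 4-methoxyphenyl in place of furan-2-yl on a double-bonded chain carbon bound to a double-bonded chain carbon.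

For the measured compounds named here, only one measured step bears on this change. It exchanged 3-methoxyphenyl for furan-2-yl at that same place and gave a 1.0-fold lower number from compound 1 to compound 2 (0.00 log units; within the scatter). Going by the values given here, a single step is thin evidence, and the data hold no measured compound with 4-methoxyphenyl at this place. Even so, no step beyond the scatter is expected in this assay.

The expected step is a 1.1-fold lower number from compound 2 to compound 3 (0.03 log units; within the scatter). Compound 3 is estimated at 11000 nM, with an expected range of 5000 nM to 25000 nM.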

Compound 3, half-maximal inhibitory concentration: 11300 nM
The estimate for compound 3 lay 1.0-fold (0.01 log units) below the measured number; measured number inside the range.
By their numbers in this assay, from the lowest: compounds 3, 2 and 1 (each within the scatter of the next).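

In this assay, putting 4-methoxyphenyl in place of furan-2-yl on this chain carbon gives a step within the scatter (a 1.0-fold lower number from compound 2 to compound 3 (0.02 log units; within the scatter)), and putting it in place of 3-methoxyphenyl does the same (a 1.1-fold lower number from compound 1 to compound 3 (0.02 log units; within the scatter)). Among the compounds shown here, compounds 1 and 2 alone showed only that these two groups read alike; compound 3 adds that a five-membered ring with oxygen and a carbon-only six-membered ring read alike with the methoxy group in either of the two named spots, so this place has not yet separated any of the three groups. No measurement here explains this sameness.

Going by these compounds, all three groups are aromatic rings without charge, so it remains open whether a phenyl ring bearing a carboxylic acid or an amine would move the number beyond the scatter. A simple methyl group at this place, with no ring at all, is equally untested among the compounds shown.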